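Cytotoxicity notes: compounds 1 to 4 in the cell screen

The source may report more compounds than this note shows. Statements on the series, on what has been measured and on what is new or still open speak of the compounds shown alone.

Measured so far:
compound 1 `O=C(Nc1cccc(-c2ccco2)c1)C1CCCN(C(=O)c2cc(C(F)(F)F)cc(C(F)(F)F)c2)C1` gives 0%
compound 2 `O=C(Nc1cccc(Oc2ccccc2)c1)C1CCCN(C(=O)c2cccc(-c3ccco3)c2)C1` gives 0%
compound 3 `CC(C)(C)CC(=O)Nc1cccc(C(=O)N2CCCC(C(=O)Nc3ccc(Cl)cc3)C2)c1` gives 0%

In an ADME assay on PC-3 cells (Homo sapiens) for cytotoxicity, read by WST assay, tested at 100 uM (a lower number here means less inhibition, a higher number more inhibition at the concentration tested (going by the name of the read-out)), compound 1 gives 0%, level with compounds 2 and 3 at the digits shown; compound 2 is the nearest and compound 3 the furthest, and neither gap rises above the scatter. Within the data shown here, no two measured compounds differ in a single place, so no measured step is available for this series.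

Compound 4 `O=C(Nc1cccc(CN2CCCC2)c1)C1CCCN(C(=O)c2cc(C(F)(F)F)cc(C(F)(F)F)c2)C1` differs from compound 1 in one place: (pyrrolidin-1-yl)methyl in place of furan-2-yl on an aromatic carbon. Among the measured compounds shown here, no measured pair covers this change, so the expectation rests on the flat readings of compounds 1, 2 and 3 alone. The step from compound 1 to compound 4 is expected to be none beyond the scatter, at a number 2 percentage points higher from compound 1 to compound 4 (within the scatter). Compound 4 is estimated at 2%, with a range from 0% to 15%.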

Compound 4, a percentage reported as inhibition, at one concentration (the size of the read-out at that concentration, not a potency): 51%
Compound 4: the middle estimate sits 49 percentage points below what was measured; measured number above the stated range.
By their numbers in this assay, from the lowest: compounds 1, 2 and 3 (each within the scatter of the next); then compound 4.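

In this assay, (pyrrolidin-1-yl)methyl in place of furan-2-yl on an aromatic carbon, meta to a large group, gives a number 51 percentage points higher from compound 1 to compound 4 (beyond the scatter). Among these compounds, this single change is therefore enough to lift the reading out of the scatter, so this position is not silent, which the earlier compounds, with no single-place step among them, could not show. Nothing on hand accounts for the step.

Still open, from the compounds shown here alone, is whether the gain follows the pyrrolidine nitrogen or merely the loss of furan-2-yl. An open-chain dimethylaminomethyl group, a morpholin-4-ylmethyl group or a carboxylic acid at this position would help separate these readings.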